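This account rests on a few compounds, and the source may have more. Where it says the series, first, only, none or still open, it means among the compounds named here.

Measured in a functional assay on K-562R cells (Homo sapiens) for cytotoxicity, read by MTT assay, with a stated time of 48 h; on this read-out lower numbers stand for stronger inhibition and higher numbers for weaker inhibition:
- Compound 1 `COc1cc(NC(=O)n2cc(-c3ccc(O)cc3)n(-c3cc(OC)c(OC)c(OC)c3)c2=O)cc(OC)c1OC`: > 50000 nM, a limit
- Compound 2 `COc1ccc(-c2cn(C(=O)Nc3cc(OC)c(OC)c(OC)c3)c(=O)n2-c2cc(OC)c(OC)c(OC)c2)cc1OC`: > 50000 nM, a limit
- Compound 3 `COc1ccc(-c2cn(C(=O)Nc3cc(OC)c(OC)c(OC)c3)c(=O)n2-c2cc(OC)c(OC)c(OC)c2)cc1N`: 9400 nM

Among the measured compounds shown here, compound 3 holds the only true number in the set, while the other two values sit at a limit (the limit of > 50000 nM in this assay, at which 2 of the 3 values shown sit). Compound 4 `COc1ccc(-c2cn(C(=O)Nc3cc(OC)c(OC)c(OC)c3)c(=O)n2-c2cc(OC)c(OC)c(OC)c2)cc1O` differs from compound 3 by hydroxy in place of amino on an aromatic carbon. Amino in place of methoxy gave an at least 5.3-fold lower number from compound 2 to compound 3 (0.72 log units; beyond the scatter). The change from 4-hydroxyphenyl to 3-amino-4-methoxyphenyl gave an at least 5.3-fold lower number from compound 1 to compound 3 (0.72 log units; beyond the scatter). The remaining step, a step that the two limits leave unreadable from compound 1 to compound 2, adds nothing. For the measured compounds named here, no measured step swaps amino for hydroxy directly, so part of the gain in this assay is expected to be lost. The expected change is a 2.1-fold higher number from compound 3 to compound 4 (0.33 log units; beyond the scatter), a small step toward a higher number. Compound 4 is estimated at 20000 nM, with an expected range of 5000 nM to 50000 nM.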

Compound 4, half-maximal inhibitory concentration: > 50000 nM
Compound 4: only a limit was reported (the forecaster's own chance of this, stated with the estimate: 30%); middle value at least 2.5-fold (0.39 log units) from the limit.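

Hydroxy in place of amino gave an at least 5.3-fold higher number from compound 3 to compound 4 (0.72 log units; beyond the scatter) in this assay, so at this place, ortho to a methoxy group, the amino group cannot be exchanged for hydroxy without loss, though the two match in hydrogen-bond donors and acceptors. The steps from compound 4 to the other two limit compounds join two limits and cannot be read. Of amino, methoxy and hydroxy at this place, only amino, in compound 3, gives a true number rather than a limit: the limit of > 50000 nM in this assay, at which 3 of the 4 values shown sit.

On these data alone, whether a methylamino or an acetylamino group at this place keeps the activity of compound 3 remains open. As far as these compounds go, how far hydroxy and methoxy differ here also remains open.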